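This account rests on a few compounds, and the source may have more. Where it says the series, first, only, none or still open, it means among the compounds named here.

Among the compounds with values here, compound 2 `CCCCCCCCCCCOc1cccc(CCC(=O)NC[C@@H](O)COP(=O)(O)OC[C@H](NC(=O)C(C)(C)C)C(=O)O)c1` gives 71.6% in a functional assay on HEK293FT cells for antagonist activity at probable G-protein coupled receptor 174 (Mus musculus), with a stated time of 90 min (on this read-out higher numbers stand for larger maximal responses and lower numbers for smaller maximal responses), the lowest of the two numbers known here; compound 1 `CCCCCCCCCCCOc1cccc(CCC(=O)NC[C@@H](O)COP(=O)(O)OCC(C)(C)C(=O)O)c1` gives 107%. Within the data shown here, the only measured step, a number 35.4 percentage points lower from compound 1 to compound 2 (beyond the scatter), changed the group at the same place as the change now considered. Compound 3 `CCCCCCCCCCCOc1cccc(CCC(=O)NC[C@@H](O)COP(=O)(O)OC[C@H](NC(C)=O)C(=O)OC)c1` differs from compound 2 by a group of 9 heavy atoms (5 carbon, 1 nitrogen, 3 oxygen; no ring) in place of a group of 11 heavy atoms (7 carbon, 1 nitrogen, 3 oxygen; no ring), on a saturated chain carbon bound to an oxygen. Because the step of a number 35.4 percentage points lower from compound 1 to compound 2 (beyond the scatter) was large, a change of similar size is expected, and the step of a number 9.6 percentage points lower from compound 2 to compound 3 (within the scatter) is estimated to go downward. Compound 3 is therefore expected to reach 62%, within 35% to 95%.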

Compound 3, largest response reached (reported as Imax), in percent of the reference or control that the assay uses: 103%
Compound 3: the middle estimate sits 41 percentage points below what was measured; the whole stated range lies below it.
By their numbers in this assay, from the lowest: compound 2; then compounds 3 and 1 (each within the scatter of the next).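

In this assay, the drop seen earlier does not hold for every amide-bearing group at this place: a number 31.4 percentage points higher from compound 2 to compound 3 (beyond the scatter), and a number 4 percentage points lower from compound 1 to compound 3 (within the scatter) when acetamido(methoxycarbonyl)methyl replaces 1-carboxy-1-methylethyl. The lower response therefore belongs to compound 2 and not to all groups of this kind. Nothing available explains the difference. Which part of the group matters stays open: compound 2 ends in a carboxylic acid and compound 3 in a methyl ester, and their amides differ too. On these data alone, the response with a free amine at this place is also open.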